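Ethyl to allyl on the shared core: an untested extension

A few compounds are considered here, and "the series" means these few. Any claim that something is new, unique, unknown or untested is made for them only; others in the source may bear on it.

Measured compounds:
Compound 1, `CCNc1nc(NCc2ccc(NC(=O)c3ccc(F)cc3)cc2)c2ccccc2n1`, gives 1400 nM in a functional assay on HCT-116 cells (Homo sapiens) for inhibition, read by luminescence and resazurin assay, with a stated time of 3 days; on this read-out higher numbers stand for weaker inhibition and lower numbers for stronger inhibition.
Compound 2, `CN(C)c1nc(NCc2ccc(NC(=O)c3ccncc3)cc2)c2ccccc2n1`, gives 15000 nM in this assay.
Compound 3, `CCNc1nc(NCc2ccc(C(=O)Nc3ccc(F)cc3)cc2)c2ccccc2n1`, gives 1900 nM in this assay.

Compound 3 sits between the other two numbers. Its nearest neighbour is compound 1: the change a 1.4-fold higher number from compound 1 to compound 3 (0.13 log units; within the scatter) is within the scatter, so the two cannot be told apart. Among the compounds with values here, compound 2, which differs from compound 3 in more than one place, gives a considerably higher number, and no single step connects it to compound 3.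

Compound 4, `C=CCNc1nc(NCc2ccc(C(=O)Nc3ccc(F)cc3)cc2)c2ccccc2n1`, is not yet measured. It differs from compound 3 by vinyl in place of methyl on a saturated chain carbon bound to a nitrogen on an aromatic ring. Within the data shown here, no measured step touches this position: the only single-place step available, from compound 1 to compound 3, concerns the amide and not the chain on the ring nitrogen. With nothing to lean on, the step from compound 3 to compound 4 in this assay is expected to stay within the scatter, no change at the digits printed from compound 3 to compound 4 (within the scatter). Compound 4 is therefore estimated at 1900 nM, with a range from 800 nM to 4500 nM.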

Compound 4, half-maximal inhibitory concentration: 14000 nM
Compound 4: middle estimate off by 7.4-fold (0.87 log units), on the low side, outside the stated range (above it).
By their numbers in this assay, from the lowest: compounds 1 and 3 (each within the scatter of the next); then compounds 4 and 2 (each within the scatter of the next).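

The chain on the ring nitrogen proves not to be a silent position: in this assay, ethylamino to allylamino gives a 7.4-fold higher number from compound 3 to compound 4 (0.87 log units; beyond the scatter), a step beyond the scatter and the first such step among these compounds. Within the data shown here, the only earlier single-place step, a 1.4-fold higher number from compound 1 to compound 3 (0.13 log units; within the scatter), concerned the amide and stayed within the scatter. On compound 3, then, vinyl in place of methyl on this chain is enough to weaken inhibition in this cell read-out, but nothing available explains this result.

The compounds shown leave open whether the double bond or the added carbon accounts for the step, a question that a saturated propyl chain on the same nitrogen would address. They also leave open whether allylamino has the same effect alongside the amide of compound 1.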